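A few compounds are considered here, and "the series" means these few. Any claim that something is new, unique, unknown or untested is made for them only; others in the source may bear on it.

Within the data shown here, compound 2 `CCN(CC)S(=O)(=O)c1ccc(S(=O)(=O)N2CCC[C@@H](C(=O)NC3CN(C(=O)NC(C)(C)C)C3)C2)cc1` gives 1400 nM in a functional assay on MIA PaCa-2 cells (Homo sapiens) for inhibition, read by MTT assay, with a stated time of 3 days (on this read-out lower numbers stand for stronger inhibition and higher numbers for weaker inhibition), the highest of the two numbers so far; compound 1 `CCN(CC)S(=O)(=O)c1ccc(S(=O)(=O)N2CCC[C@@H](C(=O)N[C@@H]3CCN(C(=O)OC(C)(C)C)C3)C2)cc1` gives 500 nM. Compound 3 `CCN(CC)S(=O)(=O)c1ccc(S(=O)(=O)N2CCC[C@@H](C(=O)N[C@H]3CCN(C(=O)OC(C)(C)C)C3)C2)cc1` differs from compound 2 by 1-(tert-butoxycarbonyl)pyrrolidin-3-yl in place of 1-((tert-butyl)carbamoyl)azetidin-3-yl on an amide-type nitrogen. Among the measured compounds shown here, the one measured step that bears on this, from compound 1 to compound 2, was the reverse exchange and gave a 2.8-fold higher number from compound 1 to compound 2 (0.45 log units; beyond the scatter). Compound 3 carries the entering group with the opposite defined stereocentre from compound 1, so the return is expected but not assured: for compound 3 the estimated step is a 2.3-fold lower number from compound 2 to compound 3 (0.37 log units; beyond the scatter), an expected value of 600 nM, ranging from 200 nM to 2000 nM.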

Compound 3, half-maximal inhibitory concentration: 170 nM
Beside the measured number, compound 3's estimate is 3.5-fold (0.55 log units) above it; the whole stated range lies above it.
By their numbers in this assay, from the lowest: compound 3; then compound 1; then compound 2.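

Configuration alone changes the number at this position: with a stereocentre at a saturated ring carbon drawn S rather than R, the result is a 2.9-fold lower number from compound 1 to compound 3 (0.47 log units; beyond the scatter). Exchanging 1-((tert-butyl)carbamoyl)azetidin-3-yl for the S form of 1-(tert-butoxycarbonyl)pyrrolidin-3-yl on the amide-type nitrogen gives an 8.2-fold lower number from compound 2 to compound 3 (0.92 log units; beyond the scatter), so the outcome of this exchange depends on which form enters. That dependence can be traced to a single feature: the fact that compounds 1 and 3 differ only in the configuration as drawn. Still open, going by these compounds, is whether the lower number for the S form persists when a free amine replaces the tert-butoxycarbonyl group.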